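Trifluoromethyl in place of methyl: working notes on the series

A few compounds are considered here, and "the series" means these few. Any claim that something is new, unique, unknown or untested is made for them only; others in the source may bear on it.

Measured so far:
Compound 1, `Cc1cccc(Cn2c(Cl)nc3cc(Cl)c(Cl)cc32)c1`: in a functional assay on KB cells (Homo sapiens) for inhibition (on this read-out higher numbers stand for weaker inhibition and lower numbers for stronger inhibition), compound 1 gives > 100000 nM, which is a limit of the assay and not a number.
Compound 2, `FC(F)(F)c1cccc(Cn2c(Cl)nc3cc(Cl)c(Cl)cc32)c1`: in this assay compound 2 gives > 100000 nM, again a limit.
Compound 3, `Cc1ccc(Cn2c(Br)nc3cc(Cl)c(Cl)cc32)cc1`: in this assay compound 3 gives > 100000 nM, also a limit.

The change from compound 1 to compound 2 is trifluoromethyl in place of methyl on an aromatic carbon. Both values are limits, so the step is a step that the two limits leave unreadable from compound 1 to compound 2; nothing about its size can be read. All three measured values sit at the same point, namely (the limit of > 100000 nM in this assay, at which 3 of the 3 values shown sit).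

The core of compound 3 differs from the core of compound 1; the difference between the two cores is not broken down here.

Compound 4, `FC(F)(F)c1ccc(Cn2c(Br)nc3cc(Cl)c(Cl)cc32)cc1`, is not yet measured. It carries the same kind of change relative to compound 3 as compound 2 does relative to compound 1: trifluoromethyl in place of methyl on an aromatic carbon. The place is not identical, since in compound 2 the trifluoromethyl sits meta to a large group and in compound 4 para to a large group, so this is the same kind of change, not the same change.

The expectation for compound 4 rests on compound 3, whose value is a limit. The step from the measured pair is unreadable, so no direction can be taken from it. For compound 4 in this assay the estimated value is 150000 nM, with an expected range from 40000 nM to 600000 nM, and the step this estimate means is a step that the limit leaves unreadable from compound 3 to compound 4; most likely the assay will again report only a limit.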

Compound 4, half-maximal inhibitory concentration: > 100000 nM
Compound 4: a limit, no number (the forecaster's own chance of this, stated with the estimate: 88%); the middle value is on the limit's open side.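

Among these compounds, compound 3 and compound 4 both give only a limit of the assay and not a number, so the step between them cannot be read and the result adds no new step. All values shown stand at one point: the limit of > 100000 nM in this assay, at which 4 of the 4 values shown sit. The compounds shown leave open whether trifluoromethyl in place of methyl on an aromatic carbon alters inhibition in this assay at all.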